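This account rests on a few compounds, and the source may have more. Where it says the series, first, only, none or still open, it means among the compounds named here.

Measured compounds:
compound 1, `Cc1nc(C2CC2)cc2nn(-c3ccccc3)cc12`: in a functional assay on MCF7 cells (Homo sapiens) for inhibition, read by fluorescence, with a stated time of 72 h (a higher number here means a weaker inhibitor of growth, a lower number a stronger inhibitor of growth), compound 1 gives 63500 nM.
compound 2, `Cc1nc(CCO)cc2nn(-c3ccccc3)cc12`: compound 2 reaches only > 100000 nM, which is a limit of the assay and not a number.
compound 3, `Cc1nc(-c2ccccc2)cc2nn(-c3ccccc3)cc12`: compound 3 gives 11000 nM.

Among the values that are numbers, compound 3 stands lowest, so it is the strongest inhibitor of growth in this set. The value of compound 2 sits at the limit of > 100000 nM in this assay, at which 1 of the 3 values shown sits. Compound 4, `Cc1nc(-c2ccsc2)cc2nn(-c3ccccc3)cc12`, differs from compound 3 by one change: thiophen-3-yl in place of phenyl on an aromatic carbon. For the measured compounds named here, two measured steps bear on this change, and both lead to compound 3 by placing an aromatic ring at this position: a 5.8-fold lower number from compound 1 to compound 3 (0.76 log units; beyond the scatter) and an at least 9.0-fold lower number from compound 2 to compound 3 (0.95 log units; beyond the scatter). In both, the number falls once an aromatic ring replaces a cyclopropyl or a 2-hydroxyethyl group. Going by the values given here, the change to compound 4 keeps an aromatic ring and alters only its size and one ring atom; no measured step compares two aromatic rings at this position. The step of a 1.1-fold higher number from compound 3 to compound 4 (0.04 log units; within the scatter) is therefore expected to stay within the scatter, with no definite direction. Compound 4 is estimated to give 12000 nM, with a range from 5000 nM to 30000 nM.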

Compound 4, concentration for 50% growth inhibition: 22200 nM
Compound 4: middle estimate off by 1.9-fold (0.27 log units), on the low side; the range from low to high includes it.
By their numbers in this assay, from the lowest: compounds 3 and 4 (each within the scatter of the next); then compound 1. At a limit, above all of these: compound 2.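

Placing thiophen-3-yl on this aromatic carbon in place of phenyl gives a 2.0-fold higher number from compound 3 to compound 4 (0.30 log units; within the scatter) in this assay, so the first comparison of two aromatic rings here shows that a five-membered ring with sulfur serves as well as a six-membered ring of carbon only. The second ring also keeps its advantage over the non-aromatic groups, with a 2.9-fold lower number from compound 1 to compound 4 (0.46 log units; beyond the scatter) and an at least 4.5-fold lower number from compound 2 to compound 4 (0.65 log units; beyond the scatter) together showing that the earlier gain was not confined to phenyl. That second step has only a floor, as compound 2 sits at a limit and not at a number: the limit of > 100000 nM in this assay, at which 1 of the 4 values shown sits.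

The compounds shown leave open how a pyridine ring, a thiophen-2-yl ring or a phenyl carrying a chlorine or an amine would read at this position. They also leave open whether any group here can bring the number much lower.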